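The source may hold more compounds than are shown below. What is called first, only, known or untested is meant among the compounds shown, and "the series" means these compounds.

The set comprises four compounds built on the shared core: compound 1 `c1ccc2c(c1)CN[C@@H](CN(CC[C@H]1CCCNC1)[C@H]1CCCc3cccnc31)C2`, compound 2 `c1cnc(CN(CCCN2CCNCC2)[C@H]2CCCc3cccnc32)nc1`, compound 3 `c1cnc2c(c1)CCC[C@@H]2N(CCCN1CCNCC1)Cc1nc2ccccc2s1` and compound 4 `c1cnc2c(c1)CCC[C@@H]2N(CCCN1CCNCC1)Cc1nc2ccccc2[nH]1`. In an ADME assay for permeability, using PAMPA, with a stated time of 4 h, at pH 7.4 (a lower number here means that the compound crosses the layer more slowly, a higher number that the compound crosses the layer faster), compound 1 gives 55 nm/s. In this assay compound 2 gives 31 nm/s. Within the data shown here, these are the only two numbers recorded, and they lie within the scatter of each other, so neither compound can be separated from the other on this evidence. For compound 3 the entry in this assay reads "not determined" (no result reported), so it adds nothing to the comparison.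

The account follows the step from compound 2 to compound 4. The structural change is 1H-benzimidazol-2-yl in place of pyrimidin-2-yl on a saturated chain carbon bound to an amine nitrogen. The amine and the chain to the piperazine are kept; only the aromatic group on the chain carbon is exchanged.

Among the measured compounds shown here, no pair of measured compounds differs in this single place, so the size of the step is not known from the data. Compound 4 is expected to give 50 nm/s in this assay, within a range from 20 nm/s to 120 nm/s. The step this implies, a 1.6-fold higher number from compound 2 to compound 4 (0.21 log units; within the scatter), is estimated to be modest, upward, and close to the edge of the scatter.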

Compound 4, apparent permeability: 146 nm/s
Beside the measured number, compound 4's estimate is 2.9-fold (0.47 log units) below it; the measured number lies above the stated range.
By their numbers in this assay, from the lowest: compounds 2 and 1 (each within the scatter of the next); then compound 4.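

Among these compounds, the exchange of pyrimidin-2-yl for 1H-benzimidazol-2-yl on a saturated chain carbon bound to an amine nitrogen is the first change at this position whose size can be read: in this assay it gives a 4.7-fold higher number from compound 2 to compound 4 (0.67 log units; beyond the scatter) with the amine and the chain to the piperazine kept. Among the compounds shown here, this shows that the aromatic group on this chain carbon can on its own carry the number beyond the scatter, which no earlier pair could show, since none differed in this single place. Nothing available bears on the reason for the step.

The change brings in a six-membered aromatic ring of carbon only and a hydrogen-bond donor together, and the compounds shown do not tell these two apart. As far as these compounds go, whether a 1-methyl-1H-benzimidazol-2-yl group or a plain phenyl group on the same carbon would give a number closer to that of compound 4 or to that of compound 2 remains open, as does whether the step would hold with a longer chain to the piperazine.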